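The compounds below may be only part of what the source reports. "The series", "measured", "known", "first", "only" and "open" are said of these compounds alone.

Compound 1 `Cc1ccc(C(=O)Nc2cc3nc(C4CCCCC4)[nH]c3cc2N(C)C)cc1` sits at a limit in an ADME assay on Vero cells (Chlorocebus sabaeus) for cytotoxicity, read by resazurin assay, with a stated time of 3 days; on this read-out higher numbers stand for weaker inhibition and lower numbers for stronger inhibition: in that assay compound 1 gives > 100 ug/mL, which is a limit of the assay and not a number. Compound 2 `CCN(CC)c1cc2[nH]c(C3CCCCC3)nc2cc1NC(=O)c1ccc(C)cc1` likewise reaches only a limit, > 100 ug/mL. The step that the two limits leave unreadable from compound 1 to compound 2 therefore cannot be read, and the limit of > 100 ug/mL in this assay, at which 2 of the 2 values shown sit, is the whole of the evidence. Compound 3 `CCOCCOC(=O)Nc1cc2nc(C3CCCCC3)[nH]c2cc1N(C)C` differs from compound 1 by 2-ethoxyethoxy in place of 4-methylphenyl on a carbonyl carbon. Among the measured compounds shown here, no measured step bears on that change, so no movement beyond the scatter in this assay is expected. Compound 3 is estimated at 100 ug/mL, between 50 ug/mL and 200 ug/mL, an expected step of a number no higher from compound 1 to compound 3 (the limit leaves the size open) that most likely leaves it at the limit.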

Compound 3, half-maximal inhibitory concentration: > 100 ug/mL
Compound 3: a limit, no number; the forecaster's own chance of this, stated with the estimate: 85%; the middle value lies on the limit itself.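

Among the compounds shown here, compound 3 ends at a limit in this assay and not at a number, as compound 1 does, so no step between them can be read: the limit of > 100 ug/mL in this assay, at which 3 of the 3 values shown sit. The compounds shown leave open how far any of them lies from that limit, and whether either change moves the read-out at all.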